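Phenyl substitution at the saturated ring carbon, step to compound 4

This account rests on a few compounds, and the source may have more. Where it says the series, first, only, none or still open, it means among the compounds named here.

Compound 1 `COC(=O)C1=C(C)N=C(C)/C(=C(\O)OC)C1c1ccccc1Cl` gives 2.19 nM in a functional assay (muscle tissue) with Cavia porcellus as the target; a higher number here means that more compound is needed for the effect, a lower number that less compound is needed; compound 2 `COC(=O)C1=C(C)N=C(C)/C(=C(\O)OC)C1c1ccc(I)cc1` gives 22900 nM; compound 3 `COC(=O)C1=C(C)N=C(C)/C(=C(\O)OC)C1c1cc(Cl)cc(Cl)c1` gives 93.3 nM. Compound 3 thus sits second of the three measured numbers, with compound 1 nearest at a 43-fold higher number from compound 1 to compound 3 (1.63 log units; beyond the scatter) and compound 2 furthest at a 250-fold lower number from compound 2 to compound 3 (2.39 log units; beyond the scatter). Compound 4 `COC(=O)C1=C(C)N=C(C)/C(=C(\O)OC)C1c1cccc(C)c1` is not yet measured. It differs from compound 3 in one place: 3-methylphenyl in place of 3,5-dichlorophenyl on a saturated ring carbon.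

All three measured steps change the group on this saturated ring carbon and all are large: a 10000-fold higher number from compound 1 to compound 2 (4.02 log units; beyond the scatter), a 43-fold higher number from compound 1 to compound 3 (1.63 log units; beyond the scatter), a 250-fold lower number from compound 2 to compound 3 (2.39 log units; beyond the scatter). Within the data shown here, none of them swaps a 3,5-dichlorophenyl for a 3-methylphenyl, so no step bears directly on the change. Among the measured compounds shown here, the measured steps show only that the number in this assay moves strongly with the pattern on the phenyl ring, with compound 2 showing the highest number and compound 1 the lowest. A moderate rise from compound 3 is expected, within wide bounds: the estimated step is a 2.1-fold higher number from compound 3 to compound 4 (0.33 log units; beyond the scatter). Compound 4 is therefore estimated at 200 nM, in the range 25 nM to 1600 nM.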

Compound 4, half-maximal effective concentration: 110 nM
Estimate against measurement, compound 4: 1.8-fold (0.26 log units) above, within the range that was stated.
By their numbers in this assay, from the lowest: compound 1; then compounds 3 and 4 (each within the scatter of the next); then compound 2.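

In this assay, a 1.2-fold higher number from compound 3 to compound 4 (0.07 log units; within the scatter) shows that 3-methylphenyl and 3,5-dichlorophenyl on this saturated ring carbon cannot be told apart, even though the two groups share no substituent. The large gaps remain on both sides, with a 210-fold lower number from compound 2 to compound 4 (2.32 log units; beyond the scatter) and with a 50-fold higher number from compound 1 to compound 4 (1.70 log units; beyond the scatter), so compound 3 and compound 4 now form a shared level between compound 1 and compound 2. Nothing available explains why these two groups give matching numbers.

Still open, going by these compounds, is how a 3-chlorophenyl or a 2-methylphenyl would fall relative to this level and to compound 1. Equally open, on these data alone, is how a phenyl ring bearing an amine or a carboxylic acid would behave at this carbon.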